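The source may hold more compounds than are shown below. What is called first, only, known or untested is meant among the compounds shown, and "the series" means these compounds.

Of the compounds shown here, three on a shared core have been measured in an ADME assay on BJ cells (Homo sapiens) for cytotoxicity, with a stated time of 72 h; on this read-out higher numbers stand for an effect only at larger amounts of compound and lower numbers for an effect already at smaller amounts. Compound 1 `Cc1cc(NC(=O)Nc2ccccc2F)c2ccccc2n1` carries a 2-fluorophenyl on an amide-type nitrogen. In this assay compound 1 gives only a limit of the assay, > 25000 nM. Compound 2 `Cc1cc(NC(=O)Nc2cccc(Cl)c2)c2ccccc2n1` has 3-chlorophenyl in place of 2-fluorophenyl on an amide-type nitrogen. In this assay compound 2 likewise gives only a limit, > 25000 nM. Compound 3 `CSc1ccccc1NC(=O)Nc1cc(C)nc2ccccc12` has methylsulfanyl in place of fluoro on an aromatic carbon. In this assay compound 3 also gives only a limit, > 25000 nM. So compound 3 stands exactly where the other two stand, at the limit of > 25000 nM in this assay, at which 3 of the 3 values shown sit, and none of the three can be set above or below another.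

The step from compound 3 to compound 4 `Cc1cc(NC(=O)Nc2ccccc2[N+](=O)[O-])c2ccccc2n1` is this: nitro in place of methylsulfanyl on an aromatic carbon. Among the measured compounds shown here, two measured steps bear on it, each altering the same part of the structure: a step that the two limits leave unreadable from compound 1 to compound 2 and a step that the two limits leave unreadable from compound 1 to compound 3. Neither has a readable size, as both their ends rest on (the limit of > 25000 nM in this assay, at which 3 of the 3 values shown sit). Nothing measured suggests that compound 4 would leave that limit, so the expected step is a step that the limit leaves unreadable from compound 3 to compound 4, nothing beyond the scatter. Compound 4 is therefore estimated at about 30000 nM, most likely again reported only as a limit, with a range from 10000 nM to 100000 nM.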

Compound 4, half-maximal effective concentration: > 25000 nM
Compound 4 was reported as a limit; the forecaster's own chance of this, stated with the estimate: 85%; the middle value does not contradict the limit.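

In this assay compound 4 again gives only a limit, > 25000 nM. The steps from compound 1 and compound 3 to compound 4 cannot be read, as all four compounds rest on the same mark: the limit of > 25000 nM in this assay, at which 4 of the 4 values shown sit. The compounds shown leave open whether any change on this shared core would give an effect on these cells at a readable concentration.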